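This account rests on a few compounds, and the source may have more. Where it says the series, first, only, none or still open, it means among the compounds named here.

Of the compounds shown here, three sharing one core have been measured in a functional assay on HEK293 cells for agonist activity at Free fatty acid receptor 1 (Homo sapiens), read by fluorescence and calcium flux, with a stated time of 10 min; on this read-out higher numbers stand for larger maximal responses and lower numbers for smaller maximal responses. Compound 1 `CC#C[C@@H](CC(=O)O)c1ccc(OC[C@H]2COc3ccc(Br)cc3O2)cc1` reaches 69%, compound 2 `CC#C[C@@H](CC(=O)O)c1ccc(OC[C@H]2COc3ccc(C#N)cc3O2)cc1` reaches 60%, and compound 3 `CC#C[C@@H](CC(=O)O)c1ccc(OC[C@H]2COc3ccc(CO)cc3O2)cc1` reaches 42%. Compound 3 thus stands lowest of the three: the step of a number 27 percentage points lower from compound 1 to compound 3 (beyond the scatter) and the step of a number 18 percentage points lower from compound 2 to compound 3 (beyond the scatter) both lie beyond the scatter, whereas the step of a number 9 percentage points lower from compound 1 to compound 2 (within the scatter) does not.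

Compound 4 `CC#C[C@@H](CC(=O)O)c1ccc(OC[C@H]2COc3ccc(C(C)=O)cc3O2)cc1` has not yet been measured. It differs from compound 3 in one place: acetyl in place of hydroxymethyl on an aromatic carbon. For the measured compounds named here, no measured step involves acetyl, so only the two steps ending at compound 3 bear on this change, and both show that hydroxymethyl gives the smallest response among the three groups examined. Replacing it with acetyl, which carries no hydrogen-bond donor, is therefore expected to move the response back toward the other two values rather than lower still, though the size of that recovery is uncertain. Compound 4 is expected to reach 55%, between 40% and 70%, which corresponds to an expected step of a number 13 percentage points higher from compound 3 to compound 4 (beyond the scatter).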

Compound 4, largest response reached (Emax), in percent of the reference or control that the assay uses: 51%
Estimate against measurement, compound 4: 4 percentage points above; measured number inside the range.
By their numbers in this assay, from the lowest: compounds 3, 4, 2 and 1 (each within the scatter of the next, the first and the last beyond it).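

Acetyl occupies a middle place at this aromatic carbon: the change is a number 9 percentage points higher from compound 3 to compound 4 (within the scatter) and, measured against the nitrile, a number 9 percentage points lower from compound 2 to compound 4 (within the scatter), so acetyl cannot be told apart from either neighbour, while the comparison with bromo, a number 18 percentage points lower from compound 1 to compound 4 (beyond the scatter), is the only clear gap. Swapping hydroxymethyl for a group without a hydrogen-bond donor therefore does not bring the response clearly back, and the order at this position remains a gradual slope rather than two separate levels. No measurement here explains why these groups differ.

The compounds shown leave open how an amine, a carboxylic acid or a longer chain at this aromatic carbon would compare with bromo. They also cannot separate the loss of the hydrogen-bond donor from the gain of a carbon in the change to acetyl.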